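Swapping the Amine on a Thiocarbonyl Carbon

A few compounds are considered here, and "the series" means these few. Any claim that something is new, unique, unknown or untested is made for them only; others in the source may bear on it.

Going by the values given here, of the two compounds already measured, compound 2 `COc1ccc2oc(CSC(=S)N(C(C)C)C(C)C)cc(=O)c2c1` is the only one with a number in a functional assay on MDA-MB-435S cells (Homo sapiens) for antiproliferative activity, read by MTT assay, with a stated time of 72 h; on this read-out lower numbers stand for stronger inhibition and higher numbers for weaker inhibition; in this assay compound 2 gives 22100 nM. Compound 1 `O=c1cc(CSC(=S)N2CCCCC2)oc2ccccc12` reaches only a limit of the assay rather than a number, > 25000 nM. The other of the two values therefore sits at the limit of > 25000 nM in this assay, at which 1 of the 2 values shown sits.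

Compound 3 `COc1ccc2oc(CSC(=S)N3CCCCC3)cc(=O)c2c1` differs from compound 2 by piperidin-1-yl in place of diisopropylamino on a thiocarbonyl carbon. Among the compounds with values here, no step between measured compounds is on record, so the size of the change must be judged from the pair itself: compound 1 carries the same piperidin-1-yl group and stays at a limit, while compound 2 shares its core with compound 3. The expected step from compound 2 to compound 3 is a 1.3-fold higher number from compound 2 to compound 3 (0.10 log units; within the scatter), toward weaker inhibition or within the scatter. Compound 3 is estimated at 28000 nM, between 12000 nM and 60000 nM, with a real chance that only a limit is reported.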

Compound 3, half-maximal inhibitory concentration: 1500 nM
For compound 3 the middle estimate is 19-fold (1.27 log units) above the measured one, and the stated range ends above it.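

In this assay, the place on the thiocarbonyl carbon proves able to carry a large change: piperidin-1-yl in place of diisopropylamino, with the shared core unchanged, gives a 15-fold lower number from compound 2 to compound 3 (1.17 log units; beyond the scatter). Methoxy in place of hydrogen on an aromatic carbon, with piperidin-1-yl kept, also matters and gives an at least 16-fold lower number from compound 1 to compound 3 (1.22 log units; beyond the scatter). Compound 1 stands at a limit of the assay, so this second step is a bound and not a measured size: the limit of > 25000 nM in this assay, at which 1 of the 3 values shown sits.

The compounds shown leave open whether the ring of piperidin-1-yl is what counts, or whether pyrrolidin-1-yl or morpholin-4-yl on the thiocarbonyl carbon would serve as well. They also leave open whether a chlorine atom or a hydroxy group on the aromatic carbon would match methoxy.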